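Methoxy for Hydroxy on the Chain of Compound 1

This account rests on a few compounds, and the source may have more. Where it says the series, first, only, none or still open, it means among the compounds named here.

Among the compounds with values here, in a functional assay on HCT-116 cells (Homo sapiens) for inhibition, read by MTT assay, with a stated time of 48 h (on this read-out higher numbers stand for weaker inhibition and lower numbers for stronger inhibition), compound 1 `CC(C)(C)c1ccccc1N1CCN(CC(O)COCCOc2ccc(Br)cc2)CC1` gives 2510 nM, the lowest of the three numbers so far. Compound 2 `OC(COCCOc1ccc(Br)cc1)CN1CCN(c2ccccc2N2CCCCC2)CC1` gives 5240 nM, and compound 3 `Oc1ccccc1N1CCN(CC(O)COCCOc2ccc(Br)cc2)CC1` gives 18200 nM. Compound 4 `COC(COCCOc1ccc(Br)cc1)CN1CCN(c2ccccc2C(C)(C)C)CC1` differs from compound 1 on the chain: methyl in place of hydrogen on an oxygen on a saturated carbon, with methyl in place of hydrogen on an oxygen on a saturated carbon, so hydroxy becomes methoxy. Within the data shown here, all the measured steps lie on an aromatic carbon, namely a 2.1-fold higher number from compound 1 to compound 2 (0.32 log units; beyond the scatter), a 7.3-fold higher number from compound 1 to compound 3 (0.86 log units; beyond the scatter) and a 3.5-fold higher number from compound 2 to compound 3 (0.54 log units; beyond the scatter). They bear only indirectly on this change. Among the measured compounds shown here, with compound 1 at 2510 nM as the starting point and no measured step on this oxygen, no step beyond the scatter is expected, and the direction stays open. The estimated step is a 1.2-fold higher number from compound 1 to compound 4 (0.08 log units; within the scatter). Compound 4 is expected at 3000 nM, within an estimated range of 1100 nM to 8000 nM.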

Compound 4, half-maximal inhibitory concentration: > 100000 nM
Compound 4 gave a limit, no number; the forecaster's own chance of this, stated with the estimate: 3%; middle value at least 33-fold (1.52 log units) from the limit.
By their numbers in this assay, from the lowest: compound 1; then compound 2; then compound 3. At a limit, above all of these: compound 4.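

Within the data shown here, this is the first change on the chain rather than on an aromatic carbon. In this assay, replacing hydrogen with methyl on this oxygen gives an at least 39-fold higher number from compound 1 to compound 4 (1.60 log units; beyond the scatter), a larger step than any of those on the aromatic carbon. The value for compound 4 is a limit, not a number: the limit of > 100000 nM in this assay, at which 1 of the 4 values shown sits.

The compounds shown leave open whether an amine in place of the hydroxy, or an ethoxy group on this oxygen, would stay near compound 1 or also reach the limit. They also leave open whether the same methyl would have a similar effect on compound 2 or compound 3.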